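Hydrazone aryl swap in the fibroblast cytotoxicity series

The compounds below may be only part of what the source reports. "The series", "measured", "known", "first", "only" and "open" are said of these compounds alone.

In an ADME assay on WI-38 cells (Homo sapiens) for cytotoxicity, read by MTT assay, with a stated time of 72 h (on this read-out higher numbers stand for weaker inhibition and lower numbers for stronger inhibition), the measured compounds so far:
compound 1 `CN(C)CCn1cnnc1-c1cc(Oc2ccc(NC(=O)N/N=C/c3cccc(Cl)c3Cl)cc2F)ccn1`: 6130 nM
compound 2 `CN(C)CCn1cnnc1-c1cc(Oc2ccc(NC(=O)N/N=C/c3ccc(O)c(O)c3)cc2F)ccn1`: "not determined" (no result reported)
compound 3 `CN(C)CCn1cnnc1-c1cc(Oc2ccc(NC(=O)N/N=C/c3c[nH]c4ccccc34)cc2F)ccn1`: 3620 nM
compound 4 `CN(C)CCn1cnnc1-c1cc(Oc2ccc(NC(=O)N/N=C/c3c(Cl)cccc3Cl)cc2F)ccn1`: to be measured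

Compound 3 and compound 1 cannot be separated on these numbers: a 1.7-fold lower number from compound 1 to compound 3 (0.23 log units; within the scatter). Compound 2 contributes no number.

The next step changes only the aryl group on the hydrazone carbon: 2,6-dichlorophenyl in place of 1H-indol-3-yl on a carbon with a double bond to nitrogen. For the measured compounds named here, the single measured step that bears on it is the reverse kind of exchange, a 1.7-fold lower number from compound 1 to compound 3 (0.23 log units; within the scatter), in which a dichlorophenyl gave way to the indolyl and the number moved within the scatter. Compound 4 carries a dichlorophenyl again, with the chlorines placed differently from compound 1. The expectation is therefore a small move back toward the number of compound 1, with no step beyond the scatter: the estimated step is a 1.5-fold higher number from compound 3 to compound 4 (0.18 log units; within the scatter). For compound 4 the expected value in this assay is 5500 nM, with a range from 2500 nM to 12000 nM.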

Compound 4, half-maximal inhibitory concentration: 3320 nM
The estimate for compound 4 lay 1.7-fold (0.22 log units) above the measured number, and the stated range covers the measured number.
By their numbers in this assay, from the lowest: compounds 4, 3 and 1 (each within the scatter of the next).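

In this assay, three aryl groups on the carbon with a double bond to nitrogen now carry numbers, and none separates from another: a 1.1-fold lower number from compound 3 to compound 4 (0.04 log units; within the scatter), and a 1.8-fold lower number from compound 1 to compound 4 (0.27 log units; within the scatter). For the compounds shown here, the first step adds a swap of 1H-indol-3-yl for a group with one ring and no hydrogen-bond donor, and the second adds a change of chlorine placing alone, from 2,3-dichlorophenyl to 2,6-dichlorophenyl; neither moves the number beyond the scatter, so the read-out is flat across these three groups at this position. Nothing available explains this flat result.

Still open, as far as these compounds go, is whether an aminomethyl or carboxylic acid group on the aryl ring would give a step beyond the scatter at this position. Also open, from the compounds shown here alone, is whether a longer chain elsewhere on the shared core would do so.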